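Thiosemicarbazone series: fluoro to methoxy on the aryl ring

The source may report more compounds than this note shows. Statements on the series, on what has been measured and on what is new or still open speak of the compounds shown alone.

Measured so far in a functional assay on HeLa cells (Homo sapiens) for antiproliferative activity, read by sulforhodamine B assay, with a stated time of 72 h; a lower number here means a stronger inhibitor, a higher number a weaker inhibitor:
compound 1 `Fc1ccccc1NC(=S)N/N=C/c1ccc2ccccc2n1` gives > 100000 nM
compound 2 `CN(C)C(=S)N/N=C/c1ccc2cccnc2n1` gives 970 nM
compound 3 `NC(=S)N/N=C/c1cc2cccnc2s1` gives 6290 nM

The value of compound 1 is a limit of this assay, not a number. Compound 1 thus stands at the limit of > 100000 nM in this assay, at which 1 of the 3 values shown sits. Of compound 2 and compound 3 only their two values are known; no step between them is shown.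

Compound 4 `COc1ccccc1NC(=S)N/N=C/c1ccc2ccccc2n1` is not yet measured. Against compound 1 the change is methoxy in place of fluoro on an aromatic carbon, sitting ortho to a large group. For the measured compounds named here, no measured step covers a change of this kind, so no direction is anticipated beyond the scatter. Compound 4 is expected at 100000 nM, between 30000 nM and 300000 nM. The expected step of a number no higher from compound 1 to compound 4 (the limit leaves the size open) is none beyond the scatter, with a fair chance that this assay again returns only a limit.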

Compound 4, half-maximal inhibitory concentration: > 100000 nM
Compound 4 gave a limit, no number (the forecaster's own chance of this, stated with the estimate: 60%); the middle value lies on the limit itself.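

Compound 1 and compound 4 both return only a limit, so no step can be read between them: the limit of > 100000 nM in this assay, at which 2 of the 4 values shown sit.

The compounds shown leave open whether 2-fluorophenyl to 2-methoxyphenyl changes antiproliferative activity at all.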